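A Pentyl Amide Joins a Series of Cytotoxicity Limits

The source may report more compounds than this note shows. Statements on the series, on what has been measured and on what is new or still open speak of the compounds shown alone.

Three amides built on one shared core have been examined in a functional assay on HeLa cells (Homo sapiens) for cytotoxicity, read by MTT assay, with a stated time of 24 h; on this read-out lower numbers stand for stronger inhibition and higher numbers for weaker inhibition. Compound 1 `C=CC1=C(C(=O)Nc2ccccc2)C(c2ccc(Cl)c(Cl)c2)OC1` carries a phenyl on the amide nitrogen; in this assay compound 1 gives only a limit, > 100000 nM. Compound 2 `C=CC1=C(C(=O)NCc2ccccc2)C(c2ccc(Cl)c(Cl)c2)OC1` carries a benzyl there, and compound 2 likewise returns a limit, > 100000 nM. Compound 3 `C=CC1=C(C(=O)Nc2ccccc2OC)C(c2ccc(Cl)c(Cl)c2)OC1` carries a 2-methoxyphenyl; compound 3 again gives a limit, > 100000 nM. Compound 3 thus stands nowhere distinct among the numbers shown: the limit of > 100000 nM in this assay, at which 3 of the 3 values shown sit, so no ordering of the three can be read. The steps a step that the two limits leave unreadable from compound 1 to compound 2, a step that the two limits leave unreadable from compound 1 to compound 3 and a step that the two limits leave unreadable from compound 2 to compound 3 are all of unreadable size for that reason. Compound 4 `C=CC1=C(C(=O)NCCCCC)C(c2ccc(Cl)c(Cl)c2)OC1` is not yet measured; it differs from compound 3 by pentyl in place of 2-methoxyphenyl on an amide-type nitrogen. For the measured compounds named here, none of the measured steps tells how far a change on the amide nitrogen moves the read-out; each pair of limits hides the size, and together they show only that phenyl, benzyl and 2-methoxyphenyl all sit at the limit. Compound 4 is therefore expected to remain there as well, with the step that the limit leaves unreadable from compound 3 to compound 4 expected to lie within the scatter. The estimate for compound 4 is 150000 nM, ranging from 50000 nM to 500000 nM.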

Compound 4, half-maximal inhibitory concentration: > 100000 nM
Compound 4 ended at the assay's limit; the forecaster's own chance of this, stated with the estimate: 85%; the middle value is on the limit's open side.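

No step from compound 1, compound 2 or compound 3 to compound 4 can be read in this assay, because each value is a limit and not a number: the limit of > 100000 nM in this assay, at which 4 of the 4 values shown sit.

The compounds shown leave open how far any change on the amide-type nitrogen moves the read-out, since none of them gives a value beyond the limit.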